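A few compounds are considered here, and "the series" means these few. Any claim that something is new, unique, unknown or untested is made for them only; others in the source may bear on it.

Compound 1 has the structure `COc1cccc(N2C(=O)N/C(=C\c3ccc(O)cc3)C2=O)c1` and gives > 200000 nM in a functional assay on NCI-H292 cells (Homo sapiens) for antiproliferative activity (a lower number here means a stronger inhibitor, a higher number a weaker inhibitor), a limit of the assay rather than a number. Compound 2, `Cc1cccc(N2C(=O)N/C(=C\c3ccc(O)cc3)C2=O)c1`, likewise gives > 200000 nM, also a limit. Compound 3, `O=C(NCc1ccccc1)c1cccc(N2C(=O)N/C(=C\c3ccc(O)cc3)C2=O)c1`, gives 23500 nM.

Compound 3 is thus the only one of the three with a measured number; the other two values sit at the limit of > 200000 nM in this assay, at which 2 of the 3 values shown sit. The step of an at least 8.5-fold lower number from compound 1 to compound 3 (0.92 log units; beyond the scatter) and the step of an at least 8.5-fold lower number from compound 2 to compound 3 (0.92 log units; beyond the scatter) both reach beyond the scatter, while the step that the two limits leave unreadable from compound 1 to compound 2 cannot be read because of the limit of > 200000 nM in this assay, at which 2 of the 3 values shown sit.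

Compound 4, `O=C(NCC1CCCCC1)c1cccc(N2C(=O)N/C(=C\c3ccc(O)cc3)C2=O)c1`, keeps the whole of compound 3 except for one change: cyclohexyl in place of phenyl on a saturated chain carbon bound to an amide-type nitrogen. Among the measured compounds shown here, none of the measured steps touches this position; they all concern the group on the aromatic carbon of the shared core, which compound 4 keeps unchanged as benzylcarbamoyl turning into (cyclohexylmethyl)carbamoyl. The expectation is therefore a step of a 1.1-fold higher number from compound 3 to compound 4 (0.03 log units; within the scatter), within the scatter. Compound 4 is estimated at 25000 nM, with a range from 8000 nM to 80000 nM.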

Compound 4, half-maximal inhibitory concentration: 17900 nM
Estimate against measurement, compound 4: 1.4-fold (0.15 log units) above; measured number inside the range.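

In this assay, replacing the aromatic phenyl with the non-aromatic cyclohexyl gives a 1.3-fold lower number from compound 3 to compound 4 (0.12 log units; within the scatter), so on this saturated chain carbon bound to an amide-type nitrogen, the ring's aromatic character makes no readable difference. The advantage of the carbamoyl compounds over the methyl and methoxy compounds also survives this change, as shown by an at least 11-fold lower number from compound 2 to compound 4 (1.04 log units; beyond the scatter) and an at least 11-fold lower number from compound 1 to compound 4 (1.04 log units; beyond the scatter). Both of these steps are minimum sizes only, because compound 1 and compound 2 each carry a limit rather than a number: the limit of > 200000 nM in this assay, at which 2 of the 4 values shown sit.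

As far as these compounds go, it remains open how a plain butyl chain or a carboxylic acid would behave in place of the cyclohexyl, and what a longer chain carrying the ring would do. The compounds shown also do not reveal whether an amine on the ring would shift the number beyond the scatter.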